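Swapping the sulfonyl substituent in a chlorophenoxyacetic acid series

The compounds below may be only part of what the source reports. "The series", "measured", "known", "first", "only" and "open" are said of these compounds alone.

The three measured compounds share a chlorophenoxyacetic acid core joined through an alkyne to a second aromatic ring. In a functional assay on cells for antagonist activity at prostaglandin D2 receptor 2 (Homo sapiens), read by flow cytometry, with a stated time of 10 min (on this read-out higher numbers stand for weaker inhibition and lower numbers for stronger inhibition), compound 1 `CCCS(=O)(=O)c1cccc(C#Cc2cc(Cl)ccc2OCC(=O)O)c1` gives 750 nM and compound 2 `O=C(O)COc1ccc(Cl)cc1C#Cc1ccc(CO)cc1F` gives 680 nM. Compound 3 `CN(C)S(=O)(=O)c1ccc(F)c(C#Cc2cc(Cl)ccc2OCC(=O)O)c1` gives 23 nM in this assay, the lowest of the three numbers; compound 2 sits a step beyond the scatter above it and compound 1 further still.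

Compound 4 `CCCS(=O)(=O)c1ccc(F)c(C#Cc2cc(Cl)ccc2OCC(=O)O)c1` is obtained from compound 3 by a single change: propyl in place of dimethylamino on a sulfonyl sulfur, that is dimethylsulfamoyl becoming propylsulfonyl. Among the compounds with values here, no measured pair isolates this change; compound 1 carries the propylsulfonyl group but lacks the fluorine of compound 3 and compound 4, so its number alone cannot be read as the effect of the swap. The two groups match in size and in counted donors and acceptors, so the expected step of a 1.7-fold higher number from compound 3 to compound 4 (0.24 log units; within the scatter) is modest, within or near the scatter, leaning toward a slightly higher number. Compound 4 is therefore estimated at 40 nM in this assay, with a range from 12 nM to 150 nM.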

Compound 4, half-maximal inhibitory concentration: 23 nM
Compound 4: the middle estimate sits 1.7-fold (0.24 log units) above what was measured, within the range that was stated.
By their numbers in this assay, from the lowest: compounds 3 and 4 (each within the scatter of the next); then compounds 2 and 1 (each within the scatter of the next).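

In this assay, within the data shown here, propyl in place of dimethylamino on a sulfonyl sulfur gives no change at the digits printed from compound 3 to compound 4 (within the scatter), so this swap, which no earlier pair isolated, leaves the read-out unmoved at this position. Compound 4 also separates the two differences mixed between compound 1 and compound 3: fluoro in place of hydrogen on an aromatic carbon accompanies a 33-fold lower number from compound 1 to compound 4 (1.51 log units; beyond the scatter), so with propylsulfonyl held constant, this single change carries a large step. Nothing available accounts for either result.

The compounds shown leave open whether the sulfonyl sulfur would give a similar number with a longer chain, a morpholine or a carboxylic acid on it. They also leave open whether chloro or methyl could stand in for the fluoro, and whether the fluoro step recurs with dimethylamino on the sulfur.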